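Aryl swap on the triazole nitrogen of the urea series

This account rests on a few compounds, and the source may have more. Where it says the series, first, only, none or still open, it means among the compounds named here.

Two compounds are measured in a toxicity assay on MRC5 cells (Homo sapiens) for inhibition, read by MTT assay, with a stated time of 72 h; on this read-out lower numbers stand for stronger inhibition and higher numbers for weaker inhibition. Compound 1 `COc1cccc(-n2cc(COc3cccc(NC(=O)Nc4ccc(Cl)c(C(F)(F)F)c4)c3)nn2)c1` gives 8570 nM. Compound 2 `CC(C)c1cccc(-n2cc(COc3cccc(NC(=O)Nc4ccc(Cl)c(C(F)(F)F)c4)c3)nn2)c1` gives 21400 nM, the highest of the two numbers; its nearest neighbour is compound 1, the step being a 2.5-fold higher number from compound 1 to compound 2 (0.40 log units; beyond the scatter). Compound 3 `O=C(Nc1cccc(OCc2cn(-c3ccc(I)cc3)nn2)c1)Nc1ccc(Cl)c(C(F)(F)F)c1` differs from compound 2 by 4-iodophenyl in place of 3-isopropylphenyl on an aromatic nitrogen. Among the compounds with values here, the only measured step, from compound 1 to compound 2, changed a substituent on the same aromatic ring and was modest; the present change replaces that whole ring, so a modest step with uncertain direction is expected, a 1.8-fold lower number from compound 2 to compound 3 (0.25 log units; within the scatter). For compound 3 the estimate is 12000 nM, within 4000 nM to 35000 nM.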

Compound 3, half-maximal inhibitory concentration: 6840 nM
Estimate against measurement, compound 3: 1.8-fold (0.24 log units) above; the measured number falls inside the stated range.
By their numbers in this assay, from the lowest: compounds 3 and 1 (each within the scatter of the next); then compound 2.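

On the aromatic nitrogen, 4-iodophenyl separates from 3-isopropylphenyl (a 3.1-fold lower number from compound 2 to compound 3 (0.50 log units; beyond the scatter)) but not from 3-methoxyphenyl (a 1.3-fold lower number from compound 1 to compound 3 (0.10 log units; within the scatter)). Replacing the whole aryl group therefore need not move the number beyond the scatter, and among these three compounds only compound 2 stands apart. Nothing available explains this difference.

From the compounds shown here alone, whether the iodine itself or its place on the ring matters stays open, since 4-iodophenyl alters both at once. Going by these compounds, how an aryl group carrying an amine or a carboxylic acid would read is also open.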